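Replacing a chlorinated tolyl amide with a methylsulfonyl phenyl

The source may report more compounds than this note shows. Statements on the series, on what has been measured and on what is new or still open speak of the compounds shown alone.

compound 1: `CS(=O)(=O)c1ccc(C(=O)Nc2ccc(Cl)c(-c3nnc4c(Cl)cccn34)c2)c(Cl)c1`, > 100000 nM
compound 2: `O=C(Nc1ccc(Cl)c(-c2nnc3c(Cl)cccn23)c1)c1ccccc1`, 67600 nM
compound 3: `Cc1cc(Cl)ccc1C(=O)Nc1ccc(Cl)c(-c2nnc3c(Cl)cccn23)c1`, > 100000 nM

Three amides with a shared core, differing only in the aryl group on the carbonyl carbon, have been tested in a functional assay on AN3-CA cells (Homo sapiens) for antiproliferative activity, read by MTT assay, with a stated time of 72 h; on this read-out higher numbers stand for weaker inhibition and lower numbers for stronger inhibition. Compound 2, with a plain phenyl, gives 67600 nM. For compound 3 only a limit of the assay is known, > 100000 nM. Compound 1 also sits at a limit of the assay, > 100000 nM. Among the compounds with values here, the single measured step, an at least 1.4-fold higher number from compound 2 to compound 3 (0.17 log units; that floor lies within the scatter), is small.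

Compound 4, `CS(=O)(=O)c1ccc(C(=O)Nc2ccc(Cl)c(-c3nnc4c(Cl)cccn34)c2)cc1`, differs from compound 3 in one place: 4-(methylsulfonyl)phenyl in place of 4-chloro-2-methylphenyl on a carbonyl carbon. Within the data shown here, no measured step covers this exact change, so the expectation rests on how flat the series is: the only step runs within the scatter, and the nearest measured relative of compound 4, compound 1, stands at the limit of > 100000 nM in this assay, at which 2 of the 3 values shown sit. Compound 4 is therefore expected to give roughly 100000 nM, within 40000 nM to 300000 nM, most likely again reported only as a limit. The implied step, a number no higher from compound 3 to compound 4 (the limit leaves the size open), is expected to stay within the scatter.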

Compound 4, half-maximal inhibitory concentration: > 100000 nM
Compound 4: only a limit was reported; the forecaster's own chance of this, stated with the estimate: 65%; the middle value lies on the limit itself.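

Placing methylsulfonyl on the plain phenyl of compound 2 gives an at least 1.4-fold higher number from compound 2 to compound 4 (0.17 log units; that floor lies within the scatter), so this change shows no effect that can be told from the scatter. The steps to compound 4 from compound 3 and from compound 1 cannot be read, as both ends of each are limits. Taking the chloro away from compound 1 does not bring back a measurable value, and the series now gathers at a single point: the limit of > 100000 nM in this assay, at which 3 of the 4 values shown sit.

Going by these compounds, how far compound 1, compound 3 and compound 4 truly lie past that limit stays open, so any real differences among them remain hidden. Also open, on these data alone, is whether an amine or a carboxylic acid in place of the methylsulfonyl on this phenyl would give a value clearly separate from that of compound 2.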